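The source may report more compounds than this note shows. Statements on the series, on what has been measured and on what is new or still open speak of the compounds shown alone.

Measured compounds and their values:

Compound 1, `CN1CCN(c2ccc(C3=NN(S(=O)(=O)c4ccc(C#N)cc4)C(c4ccc(N(C)C)cc4)C3)cc2)CC1`, gives 99.8% in a functional assay on MDA-MB-231 cells (Homo sapiens) for inhibition, read by sulforhodamine B assay, tested at 10 uM; a higher number here means more inhibition at the concentration tested (going by the name of the read-out), a lower number less inhibition.
Compound 2, `CC(=O)N1N=C(c2ccc(-n3cncn3)cc2)CC1c1ccc(N(C)C)cc1`, gives 7.4%.
Compound 3, `CN(C)c1ccc(C2CC(c3ccc(-n4cncn4)cc3)=NN2S(=O)(=O)c2ccc(F)cc2)cc1`, gives 12.1%.

Among these three numbers compound 3 stands second highest. Its nearest neighbour is compound 2: the step of a number 4.7 percentage points higher from compound 2 to compound 3 (within the scatter) lies within the scatter, so the two values cannot be told apart. Going by the values given here, compound 1 is far off; its value stands well beyond the scatter above that of compound 3, but compound 1 differs from compound 3 in more than one place, so no single-change step can be drawn between them.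

Compound 4, `CN(C)c1ccc(C2CC(c3ccc(-n4cncn4)cc3)=NN2S(=O)(=O)c2ccc(C#N)cc2)cc1`, is not yet measured. It differs from compound 3 in one place only: cyano in place of fluoro on an aromatic carbon. Among the compounds with values here, the only measured step, from compound 2 to compound 3, swaps the group on the ring nitrogen and says nothing directly about the swap of fluoro for cyano. That compound 1, which carries the (4-cyanophenyl)sulfonyl group, stands so much higher is suggestive but confounded by its other difference. An upward step is therefore expected, but of very uncertain size: the expected change is a number 22.9 percentage points higher from compound 3 to compound 4 (beyond the scatter). Compound 4 is estimated at 35%, within the range 5% to 80%.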

Compound 4, a percentage reported as inhibition, at one concentration (the size of the read-out at that concentration, not a potency): 32.8%
The estimate for compound 4 lay 2.2 percentage points above the measured number, within the range that was stated.
By their numbers in this assay, from the lowest: compounds 2 and 3 (each within the scatter of the next); then compound 4; then compound 1.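

In this assay, going by these compounds alone, cyano in place of fluoro on this aromatic carbon gives a number 20.7 percentage points higher from compound 3 to compound 4 (beyond the scatter), the first measured evidence that the group at this position of the sulfonyl-bound phenyl ring changes the read-out, whereas the swap from acetyl to (4-fluorophenyl)sulfonyl on the ring nitrogen gave only a number 4.7 percentage points higher from compound 2 to compound 3 (within the scatter). With the cyano form, the same kind of swap on that nitrogen gives a number 25.4 percentage points higher from compound 2 to compound 4 (beyond the scatter), so among these compounds the sulfonyl group stands clear of acetyl only when it carries cyano. The cyano group does not by itself reach the level of compound 1, since 1H-1,2,4-triazol-1-yl in place of 4-methylpiperazin-1-yl, with the (4-cyanophenyl)sulfonyl group kept, gives a number 67 percentage points lower from compound 1 to compound 4 (beyond the scatter), a large step beside the modest one from fluoro to cyano.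

From the compounds shown here alone, it remains open whether a nitro group, a methoxy group or a carboxylic acid on the same aromatic carbon would give a different number, and whether the step from fluoro to cyano would keep its size in a compound carrying 4-methylpiperazin-1-yl. Nothing available gives a reason for either step.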